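The source may report more compounds than this note shows. Statements on the series, on what has been measured and on what is new or still open speak of the compounds shown alone.

Of the compounds shown here, two of the same core have been measured. Compound 1 `Cc1cccc(NC(=O)Nc2nnc(Sc3ncnc4scc(-c5ccncc5)c34)s2)c1` carries a methyl group on its outer benzene ring, and compound 2 `O=C(Nc1cccc(Cl)c1)Nc1nnc(Sc2ncnc3scc(-c4ccncc4)c23)s1` carries a chloro at the same place. In a functional assay on HUVEC cells (Homo sapiens) for antiproliferative activity, read by MTT assay, with a stated time of 48 h (on this read-out higher numbers stand for weaker inhibition and lower numbers for stronger inhibition), compound 1 gives 12200 nM, and compound 2 gives 21000 nM. The change from one to the other was a 1.7-fold higher number from compound 1 to compound 2 (0.24 log units; within the scatter), so the two numbers cannot be told apart, and compound 2 stands alongside compound 1 rather than apart from it.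

Compound 3 `O=C(Nc1cccc(C(F)(F)F)c1)Nc1nnc(Sc2ncnc3scc(-c4ccncc4)c23)s1` is the next member. The change from compound 2 is trifluoromethyl in place of chloro on an aromatic carbon. Within the data shown here, the only step that bears on it is the one from compound 1 to compound 2, which swapped one small group for another at this very place and stayed within the scatter. By that single comparison, the step is expected to be a 1.1-fold lower number from compound 2 to compound 3 (0.02 log units; within the scatter), that is, nothing beyond the scatter. Compound 3 is therefore estimated at 20000 nM, within a range of 8000 nM to 50000 nM.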

Compound 3, half-maximal inhibitory concentration: 22400 nM
Estimate against measurement, compound 3: 1.1-fold (0.05 log units) below; the measured number falls inside the stated range.
By their numbers in this assay, from the lowest: compounds 1, 2 and 3 (each within the scatter of the next).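

Moving to trifluoromethyl gives a 1.1-fold higher number from compound 2 to compound 3 (0.03 log units; within the scatter) and moving from methyl to trifluoromethyl gives a 1.8-fold higher number from compound 1 to compound 3 (0.26 log units; within the scatter) in this assay and neither step leaves the scatter. Methyl, chloro and trifluoromethyl therefore cannot be told apart at this place on the outer benzene ring, and this now holds for three groups rather than one pair, even though trifluoromethyl holds more heavy atoms than chloro. Nothing available here gives a reason for this sameness.

The three compounds shown leave open whether any group at this place can shift the number beyond the scatter, since an amine, a carboxylic acid or a longer chain such as butyl differs from all three. They also leave open whether the same sameness would hold elsewhere on this ring.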